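This account rests on a few compounds, and the source may have more. Where it says the series, first, only, none or still open, it means among the compounds named here.

Measured in an ADME assay on Vero cells (Chlorocebus sabaeus) for cytotoxicity, read by MTT assay, with a stated time of 72 h; on this read-out lower numbers stand for higher toxicity in this test and higher numbers for lower toxicity in this test:
Compound 1 `C[C@]1(CN2CCc3nc(C4CCOCC4)ccc3C2)Cn2cc([N+](=O)[O-])nc2O1`: "not determined" (no result reported)
Compound 2 `C[C@]1(CN2CCc3nc(-c4cc(F)cc(F)c4)ccc3C2)Cn2cc([N+](=O)[O-])nc2O1`: > 32 ug/mL

Compound 1 offers no number for comparison, so compound 2 is the only reference in this assay. Compound 2 reads > 32 ug/mL, and this is a limit of the assay, not a number. The evidence therefore amounts to the limit of > 32 ug/mL in this assay, at which 1 of the 2 values shown sits.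

Compound 3 `C[C@]1(CN2CCc3nc(-c4cc(F)ccc4F)ccc3C2)Cn2cc([N+](=O)[O-])nc2O1` keeps the shared core and changes only the aryl group: 2,5-difluorophenyl in place of 3,5-difluorophenyl on an aromatic carbon. The two compounds have the same atoms, joined differently. Among the measured compounds shown here, no measured pair shows what such a change does in this assay, so the only guide is compound 2 with its limit of > 32 ug/mL. On that basis, no shift in either direction is expected beyond the usual scatter of repeated measurements. The estimated step that the limit leaves unreadable from compound 2 to compound 3 should be read in that light, and another report as a limit would not be surprising. For compound 3 the expected half-maximal cytotoxic concentration is 40 ug/mL, with an estimated range of 20 ug/mL to 64 ug/mL.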

Compound 3, half-maximal cytotoxic concentration: > 32 ug/mL
Compound 3: a limit, no number; the forecaster's own chance of this, stated with the estimate: 80%; the middle value lies beyond the limit too.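

In this assay compound 3 gives > 32 ug/mL, which is a limit of the assay and not a number. Compound 2 also stands at a limit, so no step between compound 2 and compound 3 can be read: the limit of > 32 ug/mL in this assay, at which 2 of the 3 values shown sit.

The compounds shown leave open whether 2,5-difluorophenyl in place of 3,5-difluorophenyl changes the half-maximal cytotoxic concentration at all.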